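The source may report more compounds than this note shows. Statements on the series, on what has been measured and on what is new or still open speak of the compounds shown alone.

Within the data shown here, in a functional assay on FM3A cells (Mus musculus) for antiproliferative activity, read by cell counting, with a stated time of 2 days (a lower number here means a stronger inhibitor, a higher number a weaker inhibitor), only two compounds have numbers so far. Compound 1 (`COc1cccc(Nc2nc(N)c(C(=O)c3ccccc3)s2)c1`) gives 5000 nM, and compound 2 (`COc1cc(C(=O)c2sc(Nc3ccccc3)nc2N)cc(OC)c1OC`) gives 23 nM, the lower of the two and well beyond the scatter. Compound 3 (`COc1ccc(C(=O)c2sc(Nc3ccccc3)nc2N)cc1OC`) departs from compound 2 in one place: hydrogen in place of methoxy on an aromatic carbon, ortho to a methoxy group. Among the measured compounds shown here, no measured pair shows this change alone. Compounds 1 and 2 differ in more than one place, so their gap is only a loose guide to how far the number can move in this series. A higher number is expected in this assay, beyond the scatter but probably short of that whole gap. The expected change is a 35-fold higher number from compound 2 to compound 3 (1.54 log units; beyond the scatter). Compound 3 is estimated at 800 nM, with an expected range of 150 nM to 4500 nM.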

Compound 3, half-maximal inhibitory concentration: > 10000 nM
Compound 3: a limit, no number (the forecaster's own chance of this, stated with the estimate: 4%); middle value at least 12-fold (1.09 log units) from the limit.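

Compound 3 gives > 10000 nM, which is a limit of the assay and not a number. The change of a single methoxy group to hydrogen, on an aromatic carbon ortho to a methoxy group and meta to a large group, is enough on its own to give an at least 430-fold higher number from compound 2 to compound 3 (2.63 log units; beyond the scatter) in this assay, and this is the only single-place step shown, so it is the first direct sign that this position matters strongly. How far the true step extends cannot be read, because the value of compound 3 rests on this: the limit of > 10000 nM in this assay, at which 1 of the 3 values shown sits.

The compounds shown leave open whether methoxy itself is needed at this position, or whether a hydroxyl, an ethoxy group or a fluorine atom there would keep the number close to that of compound 2. They also leave open how the other two methoxy groups contribute when each is changed alone.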